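A few compounds are considered here, and "the series" means these few. Any claim that something is new, unique, unknown or untested is made for them only; others in the source may bear on it.

Measured so far:
compound 1, `CC(=O)O[C@H]1C[C@H](C)[C@H]2C[C@H]2C2=C(COC2=O)[C@H]1[C@H](C)CCC=C(C)C` — > 10 ug/mL in a functional assay on KB cells (Homo sapiens) for cytotoxicity; a higher number here means that more compound is needed for the effect, a lower number that less compound is needed
compound 2, `CC(=O)O[C@@H]1C(=O)C2C1CC/C=C(\C)CC[C@@H]2[C@H](C)CCC=C(C)C` — > 10 ug/mL in this assay

In this assay compound 1 gives > 10 ug/mL, which is a limit of the assay and not a number. In this assay compound 2 gives > 10 ug/mL, again a limit. Both values sit at the limit of > 10 ug/mL in this assay, at which 2 of the 2 values shown sit, so compound 2 stands at the limit of what has been measured, with no number to place it against compound 1.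

Compound 3, `CC(=O)O[C@H]1C(=O)C2C1CC/C=C(\C)CC[C@@H]2[C@H](C)CCC=C(C)C`, is yet to be measured in this assay. Its difference from compound 2: the two compounds have the same atoms and bonds; at least one stereo element is drawn with a configuration in one of them and without one in the other: 1 of 6 stereo elements differ; a stereocentre at a saturated ring carbon is drawn S in compound 2 and R in compound 3. Among the compounds with values here, no measured pair differs in one place, so no measured step size is available as a guide. The step from compound 2 to compound 3 is expected to be a step that the limit leaves unreadable from compound 2 to compound 3, none beyond the scatter. In this assay compound 3 is therefore estimated at 20 ug/mL, with a range from 6 ug/mL to 70 ug/mL, and most likely reported once more as a limit rather than a number.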

Compound 3, concentration for half-maximal effect: > 10 ug/mL
Compound 3: a limit, no number; the forecaster's own chance of this, stated with the estimate: 80%; the middle value is on the limit's open side.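

No step can be read between compound 2 and compound 3 in this assay, since both values are limits and not numbers: the limit of > 10 ug/mL in this assay, at which 3 of the 3 values shown sit.

Going by these compounds, whether the saturated ring carbon stereocentre, drawn S in compound 2 and R in compound 3, affects the result in this assay stays open.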